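This account rests on a few compounds, and the source may have more. Where it says the series, first, only, none or still open, it means among the compounds named here.

Working notes on the cytotoxicity series. Three compounds sharing a core have numbers in an ADME assay on HepG2 cells (Homo sapiens) for cytotoxicity, read by luminescence, CellTiter-Glo and ATP content, with a stated time of 72 h; on this read-out lower numbers stand for an effect already at smaller amounts and higher numbers for an effect only at larger amounts of compound. Compound 1 `COc1cccc(CNCCCNc2ccnc3cc(-c4cc(C(F)(F)F)cc(C(F)(F)F)c4)ccc23)c1O` gives 940 nM in this assay. Compound 2 `COc1ccc(F)cc1CNCCCNc1ccnc2cc(Cc3ccc(F)cc3)ccc12` gives 3530 nM, and compound 3 `CC(C)(C)c1ccc(Oc2ccc3c(NCCCNCc4ccco4)ccnc3c2)cc1` gives 3100 nM. Compound 1 stands lowest of the three: the nearest is compound 3, at a gap beyond the scatter, and compound 2 lies further still, also beyond the scatter, so compound 1 is the one showing an effect at the smallest amount among the three.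

The next step leads to compound 4 `FC(F)(F)c1cc(-c2ccc3c(NCCCNCc4ccco4)ccnc3c2)cc(C(F)(F)F)c1`, not yet run in this assay. It differs from compound 1 in one place: furan-2-yl in place of 2-hydroxy-3-methoxyphenyl on a saturated chain carbon bound to an amine nitrogen. Going by the values given here, no pair of measured compounds isolates this change. Compound 3 carries the same furan-2-yl on a saturated chain carbon bound to an amine nitrogen but also differs elsewhere, so the value of compound 3, 3100 nM, is only a loose hint in this assay.

The step is expected to go upward, toward an effect only at larger amounts, and is estimated as a 2.1-fold higher number from compound 1 to compound 4 (0.33 log units; beyond the scatter), a size near the edge of the scatter rather than clearly beyond it. Compound 4 is expected to give 2000 nM in this assay, with a range from 800 nM to 5000 nM.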

Compound 4, half-maximal effective concentration in the HepG2 assay: 2410 nM
Compound 4: the middle estimate sits 1.2-fold (0.08 log units) below what was measured; measured number inside the range.
By their numbers in the HepG2 assay, from the lowest: compound 1; then compounds 4, 3 and 2 (each within the scatter of the next).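

Going by these compounds alone, at this position, on a saturated chain carbon bound to an amine nitrogen, furan-2-yl in place of 2-hydroxy-3-methoxyphenyl can now be read on its own in the HepG2 assay: the number rises modestly, with a 2.6-fold higher number from compound 1 to compound 4 (0.41 log units; beyond the scatter) as the size of the step, a reading the earlier compounds could not give, each differing from compound 1 in more than one place. In a physicochemical assay for solubility, with a stated time of 18 h, at pH 7.4 (a higher number here means a more soluble compound, a lower number a less soluble compound), compound 1 gives 32000 nM and compound 4 gives 32000 nM as its value, and the step reads no change at the digits printed from compound 1 to compound 4 (within the scatter) for this pair. In this one pair the exchange therefore shifts the cytotoxicity number while the solubility number stays the same, which is a single observation and not a pattern across the series.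

From the compounds shown here alone, it remains open whether the hydroxy group, the methoxy group or the ring of 2-hydroxy-3-methoxyphenyl carries the step, and how a plain phenyl, a pyridin-2-yl or a longer chain at this place would read. No measurement shown here bears on the reason for the step.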